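This account rests on a few compounds, and the source may have more. Where it says the series, first, only, none or still open, it means among the compounds named here.

Of the compounds shown here, three of one series have been tested for cytotoxicity in a functional assay on PC-3 cells (Homo sapiens) for cytotoxicity, read by sulforhodamine B assay, with a stated time of 5 days; a higher number here means a weaker inhibitor, a lower number a stronger inhibitor. Compound 3 `O=C(CCCCCCCc1ccccc1)CC(=O)N[C@H]1CCOC1=O` gives 2000 nM. Compound 2 `O=C(CCCCCCc1ccccc1)CC(=O)N[C@H]1CCOC1=O` gives 9000 nM, so that the change phenyl in place of benzyl on a saturated chain carbon, six bonds along the chain from a carbonyl carbon amounts to a 4.5-fold higher number from compound 3 to compound 2 (0.65 log units; beyond the scatter). Compound 1 `O=C(CCCc1ccccc1)CC(=O)N[C@H]1CCOC1=O` reaches only the limit of this assay, > 100000 nM, recorded as the limit of > 100000 nM in this assay, at which 1 of the 3 values shown sits. The difference between the core of compound 1 and that of compound 3 is not broken down here.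

Compound 4 `O=C(CCc1ccccc1)CC(=O)N[C@H]1CCOC1=O` has not been measured. It differs from compound 1 by phenyl in place of benzyl on a saturated chain carbon, two bonds along the chain from a carbonyl carbon, the same kind of change as that from compound 3 to compound 2, but set two bonds rather than six bonds along the chain from the carbonyl carbon. Since compound 1 already sits at the limit, compound 4 is expected to be weaker still, with an estimated step that the limit leaves unreadable from compound 1 to compound 4. The estimate for compound 4 in this assay is 200000 nM, between 50000 nM and 1000000 nM, most likely reported as a limit.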

Compound 4, half-maximal inhibitory concentration: > 100000 nM
Compound 4: only a limit was reported; the forecaster's own chance of this, stated with the estimate: 90%; the middle value lies beyond the limit too.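

Compound 1 and compound 4 both stand at a limit, so no step between them can be read: the limit of > 100000 nM in this assay, at which 2 of the 4 values shown sit.

Any order between these two stays open, as does whether a chain longer than that of compound 3 would lower the number further.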